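Hydroxy in place of acetoxy: compound 2 to compound 4

The compounds below may be only part of what the source reports. "The series", "measured", "known", "first", "only" and "open" are said of these compounds alone.

Of the compounds shown here, three have been measured in an ADME assay on HT-29 cells (Homo sapiens) for cytotoxicity, read by MTT assay, with a stated time of 72 h; on this read-out higher numbers stand for weaker inhibition and lower numbers for stronger inhibition. Compound 1 `COC(=O)c1cc(C2=C(c3cc(OC)c(OC)c(OC)c3)C(=O)CC2O[SiH2]C(C)(C)C)ccc1OC` gives > 100 ug/mL, which is a limit of the assay rather than a number. Compound 3 `COc1ccc(C2=C(c3cc(OC)c(OC)c(OC)c3)C(=O)C(O)C2)cc1Cl` gives < 1 ug/mL, again a limit. Compound 2 `CC(=O)OC1C/C(=N/O)C(c2ccccc2)=C1c1ccccc1` likewise gives > 100 ug/mL, a limit. Compound 2 thus stands at the limit of > 100 ug/mL in this assay, at which 2 of the 3 values shown sit, whereas compound 3 sits at the limit of < 1 ug/mL in this assay, at which 1 of the 3 values shown sits. No two of these compounds differ in a single place, so no step between measured compounds can be read. Compound 4 `O/N=C1/CC(O)C(c2ccccc2)=C1c1ccccc1` differs from compound 2 by hydrogen in place of acetyl on an oxygen on a saturated carbon. With compound 2 at a limit, the step of a number no higher from compound 2 to compound 4 (the limit leaves the size open) is expected to be none beyond the scatter in this assay. Compound 4 is therefore estimated at 100 ug/mL, within 40 ug/mL to 200 ug/mL.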

Compound 4, half-maximal inhibitory concentration: > 100 ug/mL
Compound 4 ended at the assay's limit; the forecaster's own chance of this, stated with the estimate: 70%; the middle value sits exactly at the limit.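

Compound 2 and compound 4 both stand at a limit of the assay, not at a number, and the step between them cannot be read. The compounds shown leave open whether hydroxy in place of acetoxy changes the value in this assay at all, and by how much.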